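The compounds below may be only part of what the source reports. "The series", "measured", "known", "first", "only" and "open" are said of these compounds alone.

Measured so far:
- compound 1 `CC(C)(C)c1csc(N)c1C(=O)c1ccc(Cl)cc1`: 1%
- compound 2 `CC(C)(C)Cc1c(-c2cc(F)ccc2F)sc(N)c1C(=O)c1ccc(Cl)cc1`: 1%
- compound 3 `Cc1ccc(C(=O)c2c(N)sc(-c3ccccc3)c2CC(C)(C)C)cc1`: 1%

In an assay on CHO cells for displacement of a labelled ligand from adenosine receptor A3 (Homo sapiens), read by scintillation counting, tested at 10 uM (on this read-out lower numbers stand for less inhibition and higher numbers for more inhibition at the one concentration tested (going by the name of the read-out)), compound 1 gives 1%, compound 2 gives 1% and compound 3 gives 1%. Compound 2 thus stands level with compounds 1 and 3 at the digits shown, and the three values lie within the usual scatter of one another, so no order among them can be read. Compound 4 `CC(C)(C)Cc1c(-c2ccsc2)sc(N)c1C(=O)c1ccc(Cl)cc1` has not yet been measured. It differs from compound 2 in one place: thiophen-3-yl in place of 2,5-difluorophenyl on an aromatic carbon. For the measured compounds named here, no measured pair differs in only one place, so no step between measured compounds is known. Since every measured compound sits at the same low level in this assay, a step from compound 2 to compound 4 that is expected to stay within the scatter is a number 1 percentage points higher from compound 2 to compound 4 (within the scatter). Compound 4 is therefore expected to give 2%, with a range from 0% to 12%.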

Compound 4, a percentage reported as inhibition, at one concentration (the size of the read-out at that concentration, not a potency): 4%
Estimate against measurement, compound 4: 2 percentage points below, within the range that was stated.
By their numbers in this assay, from the lowest: compounds 1, 2, 3 and 4 (each within the scatter of the next).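

In this assay, thiophen-3-yl in place of 2,5-difluorophenyl, next to the ring sulfur, gives a number 3 percentage points higher from compound 2 to compound 4 (within the scatter) on this reading. At this position, then, a five-membered aromatic ring with one sulfur and a six-membered ring of carbon only cannot be told apart, and both compounds stay at a low level. Nothing measured here offers an explanation for this. Going by these compounds, whether an amine or a carboxylic acid on this carbon would give a clearly different reading stays open. So does the effect of a longer chain in place of neopentyl.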